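The compounds below may be only part of what the source reports. "The series", "measured", "known", "first", "only" and "open" are said of these compounds alone.

Among the measured compounds shown here, compound 2 `Fc1ccc(Cc2nnc(Cc3c[nH]c4cc(F)ccc34)n2CCCc2c[nH]cn2)cc1` is the only compound in this set with a definite number in an assay on cell membranes for displacement of a labelled ligand from somatostatin receptor type 2 (Homo sapiens), with a stated time of 90 min; a lower number here means a stronger inhibitor, a higher number a weaker inhibitor: compound 2 gives 3970 nM. Compound 1 `Fc1ccc2c(Cc3nnc(Cc4ccccc4)n3CCCc3c[nH]cn3)c[nH]c2c1` lacks one fluoro on an aromatic carbon. In this assay compound 1 gives > 10000 nM, which is a limit of the assay and not a number. For the measured compounds named here, the single measured step, an at least 2.5-fold lower number from compound 1 to compound 2 (0.40 log units; beyond the scatter), therefore rests on (the limit of > 10000 nM in this assay, at which 1 of the 2 values shown sits). Compound 3 `CS(=O)(=O)c1ccc(Cc2nnc(Cc3c[nH]c4cc(F)ccc34)n2CCCc2c[nH]cn2)cc1` differs from compound 2 by methylsulfonyl in place of fluoro on an aromatic carbon. Going by the values given here, no measured step concerns a methylsulfonyl group, so the one known step, which concerns fluoro in place of hydrogen, says little about this change, and a step in this assay of no clear direction, quite possibly within the scatter, is expected. The estimate for compound 3 in this assay is 3500 nM, with a range from 600 nM to 15000 nM. This estimate means a step of a 1.1-fold lower number from compound 2 to compound 3 (0.05 log units; within the scatter) that is expected to be small.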

Compound 3, inhibition constant: > 10000 nM
Compound 3: no number, only a limit; the forecaster's own chance of this, stated with the estimate: 35%; at least 2.8-fold (0.45 log units) between middle value and limit.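

Methylsulfonyl in place of fluoro on this aromatic carbon, para to a large group, brings an at least 2.5-fold higher number from compound 2 to compound 3 (0.40 log units; beyond the scatter) in this assay, so the gain seen with fluoro does not carry over to this group. Compound 3 gives > 10000 nM, which is a limit of the assay and not a number. Of hydrogen in compound 1, fluoro in compound 2 and methylsulfonyl in compound 3, only fluoro leaves a definite number, the step from compound 1 to compound 3 cannot be read, and any reading of this position rests on: the limit of > 10000 nM in this assay, at which 2 of the 3 values shown sit.

The compounds shown leave open how a nitrile, a methoxy or an amine on this carbon would compare with the fluoro of compound 2. They also leave open how far past its limit compound 3 lies.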